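Iodo to trifluoromethyl in a level series

This account rests on a few compounds, and the source may have more. Where it says the series, first, only, none or still open, it means among the compounds named here.

Measured in a functional assay on MCF7 cells (Homo sapiens) for inhibition, read by MTT assay; on this read-out lower numbers stand for stronger inhibition and higher numbers for weaker inhibition:
- compound 1 `COc1cc2ncnc(Nc3ccc(NC(=O)c4ccc(Cl)cc4)cc3)c2cc1OC`: 30000 nM
- compound 2 `COc1cc2ncnc(Nc3ccc(NC(=O)c4ccccc4I)cc3)c2cc1OC`: 37000 nM
- compound 3 `COc1cc2ncnc(Nc3ccc(NC(=O)c4ccc(I)cc4)cc3)c2cc1OC`: 48000 nM

Compound 3 stands level with the other two, as a 1.6-fold higher number from compound 1 to compound 3 (0.20 log units; within the scatter) and a 1.3-fold higher number from compound 2 to compound 3 (0.11 log units; within the scatter) both lie within the scatter. The next change leads to compound 4 `COc1cc2ncnc(Nc3ccc(NC(=O)c4ccc(C(F)(F)F)cc4)cc3)c2cc1OC`: trifluoromethyl in place of iodo on an aromatic carbon, para to a large group. Among the compounds with values here, the closest precedent is the iodo for chloro swap in compound 3, with a 1.6-fold higher number from compound 1 to compound 3 (0.20 log units; within the scatter). Moving the iodo, seen in a 1.3-fold higher number from compound 2 to compound 3 (0.11 log units; within the scatter), also stays within the scatter. Within the data shown here, no measured compound carries trifluoromethyl, so this precedent is indirect. The expected change is small, a 1.2-fold lower number from compound 3 to compound 4 (0.08 log units; within the scatter), with no step beyond the scatter. Compound 4 is estimated at 40000 nM, with an expected range of 20000 nM to 80000 nM.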

Compound 4, half-maximal inhibitory concentration: > 100000 nM
Compound 4: no number, only a limit; the forecaster's own chance of this, stated with the estimate: 15%; middle value at least 2.5-fold (0.39 log units) from the limit.
By their numbers in this assay, from the lowest: compounds 1, 2 and 3 (each within the scatter of the next). At a limit, above all of these: compound 4.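

Compound 4 gives only a limit in this assay, not a number: the limit of > 100000 nM in this assay, at which 1 of the 4 values shown sits. Trifluoromethyl on this aromatic carbon, para to a large group, is the first change in the series to go beyond the scatter, with an at least 2.0-fold higher number from compound 3 to compound 4 (0.31 log units; beyond the scatter), an at least 2.7-fold higher number from compound 2 to compound 4 (0.43 log units; beyond the scatter) and an at least 3.3-fold higher number from compound 1 to compound 4 (0.52 log units; beyond the scatter). Chloro and iodo at this place, and the 2-iodophenyl, had stayed level with one another.

Going by these compounds, how far compound 4 lies past its limit remains open. Also open, on these data alone, is whether an amine or a carboxylic acid at this place would stay level with compound 1, compound 2 and compound 3.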